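This account rests on a few compounds, and the source may have more. Where it says the series, first, only, none or still open, it means among the compounds named here.

In a functional assay on NCI-H2009 cells (Homo sapiens) for cytotoxicity, read by fluorescence, with a stated time of 48 h (on this read-out higher numbers stand for weaker inhibition of growth and lower numbers for stronger inhibition of growth), three compounds sharing one core have been measured so far. Compound 1 (`COc1cc(C(=O)/C=C/c2ccc(O)c(O)c2)cc(OC)c1OC`) gives 1100 nM, compound 2 (`COc1ccc(/C=C/C(=O)c2cc(OC)c(OC)c(OC)c2)cc1OCCN`) gives 3600 nM and compound 3 (`COc1cc(C(=O)/C=C/c2ccc(O)cc2)cc(OC)c1OC`) gives 4500 nM. Compound 3 therefore sits level with compound 2 within the usual scatter, and both stand at the weaker end of this small set, with compound 1 clearly apart from compound 3.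

The next compound, compound 4 (`COc1cc(C(=O)/C=C/c2cccc(O)c2)cc(OC)c1OC`), has the same atoms as compound 3, joined differently: 3-hydroxyphenyl in place of 4-hydroxyphenyl on a double-bonded chain carbon bound to a double-bonded chain carbon. Here 3-hydroxyphenyl stands in place of 4-hydroxyphenyl, on a double-bonded chain carbon bound to a double-bonded chain carbon.

For the measured compounds named here, only one measured step touches this part of the molecule: a 4.1-fold higher number from compound 1 to compound 3 (0.61 log units; beyond the scatter), where hydrogen takes the place of hydroxy on an aromatic carbon. That step shows that the hydroxy groups on this ring can shift the number modestly. Going by the values given here, compound 4 keeps a hydroxy that compound 3 lacks but gives up the one that compound 3 carries, so only part of that shift seems likely to return.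

The expected change is small, towards a lower number and probably within the scatter: a 1.5-fold lower number from compound 3 to compound 4 (0.18 log units; within the scatter). For compound 4 the estimated value in this assay is 3000 nM, with an expected range from 1200 nM to 7500 nM.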

Compound 4, concentration for 50% growth inhibition: 4200 nM
Compound 4: middle estimate off by 1.4-fold (0.15 log units), on the low side, within the range that was stated.
By their numbers in this assay, from the lowest: compound 1; then compounds 2, 4 and 3 (each within the scatter of the next).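

In this assay, moving the single hydroxy from 4-hydroxyphenyl to 3-hydroxyphenyl gives a 1.1-fold lower number from compound 3 to compound 4 (0.03 log units; within the scatter), so among these compounds the place of that lone hydroxy on the ring makes no difference that can be told from the scatter. The earlier compounds shown here showed the loss of only one of the two hydroxy groups of compound 1, whereas the loss of either one can now be read, as a 4.1-fold higher number from compound 1 to compound 3 (0.61 log units; beyond the scatter) and as a 3.8-fold higher number from compound 1 to compound 4 (0.58 log units; beyond the scatter), and both steps lie beyond the scatter; in this small set, what separates the compounds is whether the ring carries two hydroxy groups, not which single one remains. Nothing available on these compounds explains this result.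

The compounds shown leave open how a plain phenyl ring with no hydroxy at all would compare, and so how much the remaining hydroxy contributes. They also leave open whether a different group in its place, such as a carboxylic acid or a fluorine atom, would give a number like that of a hydroxy.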